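Compound 4: a sulfonyl gives way to a sulfanyl

The source may report more compounds than this note shows. Statements on the series, on what has been measured and on what is new or still open speak of the compounds shown alone.

In a functional assay on DU-145 cells (Homo sapiens) for inhibition, read by trypan blue exclusion, with a stated time of 96 h (a lower number here means a stronger inhibitor of growth, a higher number a weaker inhibitor of growth), compound 1 `CN(C)c1ccc(/C=C(/Sc2ccccc2Br)C(=O)c2ccc(Br)cc2)cc1` returns only a limit (> 100000 nM). Compound 2 `CN(C)c1ccc(/C=C(/SCc2ccc(Cl)cc2)C(=O)c2ccc(Cl)cc2)cc1` also returns only a limit (> 100000 nM). Among the compounds with values here, compound 3 `Cc1ccc(S(=O)(=O)/C(=C/c2ccc(N(C)C)cc2)C(=O)c2ccc(Br)cc2)cc1` gives 50000 nM as the only actual number in the set, and the other two remain at the limit of > 100000 nM in this assay, at which 2 of the 3 values shown sit, in the same readout.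

Compound 4 `CN(C)c1ccc(/C=C(/SCc2ccc(Cl)cc2)C(=O)c2ccc(Br)cc2)cc1` differs from compound 3 by (4-chlorobenzyl)sulfanyl in place of (4-methylphenyl)sulfonyl on a double-bonded chain carbon bound to a carbonyl carbon and a double-bonded chain carbon and carries (4-chlorobenzyl)sulfanyl in place of (4-methylphenyl)sulfonyl on a double-bonded chain carbon bound to a carbonyl carbon and a double-bonded chain carbon.

Within the data shown here, the one measured step that bears on this is an at least 2.0-fold lower number from compound 1 to compound 3 (0.30 log units; that floor lies within the scatter) and it runs the reverse way, from a sulfanyl to a sulfonyl group. Compound 2 holds the same (4-chlorobenzyl)sulfanyl and shows only its limit (> 100000 nM) in this assay.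

A modest loss of growth inhibition is therefore expected, with an estimated 2.0-fold higher number from compound 3 to compound 4 (0.30 log units; within the scatter) in prospect. Compound 4 is estimated at 100000 nM with an expected range of 40000 nM to 200000 nM, and a limit in place of a number is quite possible.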

Compound 4, concentration for 50% growth inhibition: 10000 nM
Compound 4: middle estimate off by 10-fold (1.00 log units), on the high side, outside the stated range (below it).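

In this assay, the place on a double-bonded chain carbon bound to a carbonyl carbon and a double-bonded chain carbon does not depend on a sulfonyl: (4-chlorobenzyl)sulfanyl in place of (4-methylphenyl)sulfonyl gives a 5.0-fold lower number from compound 3 to compound 4 (0.70 log units; beyond the scatter). The groups around that sulfur also count, as 4-chlorobenzyl in place of 2-bromophenyl on a sulfur gives an at least 10-fold lower number from compound 1 to compound 4 (1.00 log units; beyond the scatter), and bromo in place of chloro on an aromatic carbon gives an at least 10-fold lower number from compound 2 to compound 4 (1.00 log units; beyond the scatter). These last two steps are floors rather than full sizes, each starting from a limit of the assay: the limit of > 100000 nM in this assay, at which 2 of the 4 values shown sit.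

The compounds shown leave open how a (4-chlorobenzyl)sulfonyl would read at this place, which would separate the state of the sulfur from the group it carries. On these data alone, whether an amine or a carboxylic acid in place of the chloro of the 4-chlorobenzyl would keep the gain also stays open.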